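Compound 2 to compound 4: cyano replaces difluoromethyl

The source may report more compounds than this note shows. Statements on the series, on what has been measured and on what is new or still open speak of the compounds shown alone.

Among the measured compounds shown here, in a functional assay on TMD8 cells (Homo sapiens) for cytotoxicity, read by CCK-8 assay, with a stated time of 72 h (a higher number here means a weaker inhibitor, a lower number a stronger inhibitor), compound 2 `Cn1cc(NC(=O)c2cnc3ccc(N[C@@H]4CCCNC4)nn23)c(C(F)F)n1` gives 1200 nM, the lowest number of the three measured so far. Compound 3 `Cn1cc(NC(=O)c2cnc3ccc(N[C@@H]4CCNC4)nn23)c(C(F)F)n1` gives 8300 nM, and compound 1 `Cn1cc(NC(=O)c2cnc3ccc(N4CCC[C@@H](N)C4)nn23)c(C(F)F)n1` gives 17800 nM. Compound 4 `Cn1cc(NC(=O)c2cnc3ccc(N[C@@H]4CCCNC4)nn23)c(C#N)n1` differs from compound 2 in one place, with cyano in place of difluoromethyl on an aromatic carbon.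

For the measured compounds named here, no measured step touches this group, since all three exchange the amine group instead. They still show how far a single change can move the number in this short series: a 15-fold lower number from compound 1 to compound 2 (1.17 log units; beyond the scatter) is large, and a 6.9-fold higher number from compound 2 to compound 3 (0.84 log units; beyond the scatter) is modest. Neither gives a direction for the new swap, so the expectation is loose. Going by the values given here, with compound 2 at 1200 nM, the lowest number so far, a small move towards a higher number seems the likeliest outcome. The expected change is a 2.1-fold higher number from compound 2 to compound 4 (0.32 log units; beyond the scatter). For compound 4 the estimate is 2500 nM, with an expected range from 600 nM to 9000 nM.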

Compound 4, half-maximal inhibitory concentration: 14800 nM
For compound 4 the middle estimate is 5.9-fold (0.77 log units) below the measured one; measured number above the stated range.
By their numbers in this assay, from the lowest: compound 2; then compounds 3, 4 and 1 (each within the scatter of the next, the first and the last beyond it).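

This is the only step shown at this position rather than at the amine group, and in this assay replacing difluoromethyl with cyano gives a 12-fold higher number from compound 2 to compound 4 (1.09 log units; beyond the scatter). The amine group is therefore not the only part of these molecules that can move the number by a large step: the group on the aromatic carbon next to the ring nitrogen can do so too. Nothing measured here accounts for the change in the number.

Going by these compounds, a single swap gives no trend, so it remains open how other groups at this position, such as methyl, trifluoromethyl or a chlorine atom, would compare with difluoromethyl. On these data alone, it is also open whether cyano would shift the number in the same direction when paired with the amine groups of compound 1 and compound 3.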